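Pyridyl swap on the bis-benzylidene piperidinone core

The compounds below may be only part of what the source reports. "The series", "measured", "known", "first", "only" and "open" are said of these compounds alone.

Measured compounds:
compound 1 `COc1cc(/C=C2\CN(C)C/C(=C\c3cccnc3)C2=O)cc(OC)c1` — 17900 nM
compound 2 `COc1ccc(/C=C2\CN(C)C/C(=C\c3cccnc3)C2=O)c(OC)c1OC` — 13700 nM
compound 3 `COc1cc(/C=C2\CN(C)C/C(=C\c3ccncc3)C2=O)cc(OC)c1` — 5810 nM

All three were run in a functional assay on SMMC-7721 cells (Homo sapiens) for cytotoxicity, read by MTT assay, with a stated time of 24 h; on this read-out higher numbers stand for weaker inhibition and lower numbers for stronger inhibition. Compound 1 and compound 2 carry the same pyridin-3-yl arm on different cores; the difference between the two cores is not broken down here, and their values sit within the scatter of each other. Compound 3 keeps the core of compound 1 and differs by pyridin-4-yl in place of pyridin-3-yl on a double-bonded chain carbon bound to a double-bonded ring carbon, giving a 3.1-fold lower number from compound 1 to compound 3 (0.49 log units; beyond the scatter).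

Compound 4 `COc1ccc(/C=C2\CN(C)C/C(=C\c3ccncc3)C2=O)c(OC)c1OC` is not yet measured. It relates to compound 2 by pyridin-4-yl in place of pyridin-3-yl on a double-bonded chain carbon bound to a double-bonded ring carbon, the same change as from compound 1 to compound 3, at the same place. From compound 2 to compound 4 a step of about a 2.7-fold lower number from compound 2 to compound 4 (0.44 log units; beyond the scatter) is expected, because compound 3 showed a 3.1-fold lower number from compound 1 to compound 3 (0.49 log units; beyond the scatter) over compound 1. Compound 4 is therefore estimated at 5000 nM, with a range from 2500 nM to 10000 nM.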

Compound 4, half-maximal inhibitory concentration: 9080 nM
Beside the measured number, compound 4's estimate is 1.8-fold (0.26 log units) below it, and the stated range covers the measured number.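

Pyridin-4-yl in place of pyridin-3-yl gives a 1.5-fold lower number from compound 2 to compound 4 (0.18 log units; within the scatter) in this assay, so on this core the step does not clear the usual scatter. Set beside the step on the other core, the two cannot be told apart: the same change on two cores in this assay, a 3.1-fold lower number (0.49 log units; beyond the scatter) from compound 1 to compound 3 and a 1.5-fold lower number (0.18 log units; within the scatter) from compound 2 to compound 4, 2.0-fold (0.31 log units) apart, within the scatter of two such steps. Among these compounds, this fits a change that carries over between these two cores, but it rests on only two pairs, one of them within the scatter, so it fixes no common size for the step and does not show that it holds on any further core.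

Still open, going by these compounds, is how a pyridin-2-yl arm reads in this assay. Also open, on these data alone, is whether the step persists on cores bearing an amine or a carboxylic acid in place of the methoxy groups.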